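The compounds below may be only part of what the source reports. "The series", "measured", "known", "first", "only" and "open" are said of these compounds alone.

Three compounds have so far been run through a functional assay on MCF7 cells (Homo sapiens) for cytotoxicity, read by MTT assay; a lower number here means a stronger inhibitor, a higher number a weaker inhibitor. Compound 3 `NS(=O)(=O)c1nnc(NCc2nc3ccccc3[nH]2)s1` gives 228000 nM. Compound 1 `NS(=O)(=O)c1nnc(NCc2nc3cc([N+](=O)[O-])ccc3[nH]2)s1` carries nitro in place of hydrogen on an aromatic carbon, and in this assay compound 1 gives 230000 nM, so the step of a 1.0-fold higher number from compound 3 to compound 1 (0.00 log units; within the scatter) stays within the scatter. Compound 2 `CC1=NN(Cc2nc3ccccc3[nH]2)C(=O)C1` gives 62000 nM, the lowest of the three numbers; the difference between its core and that of compound 3 is not broken down here. Compound 4 `CC1=NN(Cc2nc3cc([N+](=O)[O-])ccc3[nH]2)C(=O)C1` is compound 2 with nitro in place of hydrogen on an aromatic carbon, the same change that leads from compound 3 to compound 1, and it has not yet been measured in this assay. Because the earlier step of a 1.0-fold higher number from compound 3 to compound 1 (0.00 log units; within the scatter) lay within the scatter, compound 4 is expected to show a step of no change at the digits printed from compound 2 to compound 4 (within the scatter). Compound 4 is therefore estimated at 62000 nM, with a likely range from 30000 nM to 130000 nM.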

Compound 4, half-maximal inhibitory concentration: 281000 nM
Estimate against measurement, compound 4: 4.5-fold (0.66 log units) below; the measured number lies above the stated range.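

In this assay, nitro in place of hydrogen on an aromatic carbon gives a 4.5-fold higher number from compound 2 to compound 4 (0.66 log units; beyond the scatter). The change therefore does not carry over as a constant step between these two cores: the same change on two cores in this assay, a 1.0-fold higher number (0.00 log units; within the scatter) from compound 3 to compound 1 and a 4.5-fold higher number (0.66 log units; beyond the scatter) from compound 2 to compound 4, 4.5-fold (0.65 log units) apart, beyond the scatter of two such steps. This shows that the outcome of the change differed with the core in these two pairs, but it does not show which feature of the cores is responsible or how the change would behave on any further core.

The compounds shown leave open whether an amine or a carboxylic acid in place of the nitro would follow the step seen on the core of compound 2 or the one seen on the core of compound 3.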